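The source may report more compounds than this note shows. Statements on the series, on what has been measured and on what is new or still open speak of the compounds shown alone.

Measured so far:
- compound 1, `Cc1cc(-c2ccoc2)c2ncc(CSCCc3ccccc3)n2c1`: 100 ug/mL
- compound 2, `Cc1cc(-n2ccnc2)c2ncc(CSCCc3ccccc3)n2c1`: 20 ug/mL

Both compounds share one core and differ only in the ring attached to it. In an ADME assay on HEL cells (Homo sapiens) for cytotoxicity, with a stated time of 3 days (on this read-out higher numbers stand for lower toxicity in this test and lower numbers for higher toxicity in this test), compound 1 gives 100 ug/mL, while compound 2 gives 20 ug/mL, the lowest of the two numbers measured. Going by the values given here, the one recorded step, a 5.0-fold lower number from compound 1 to compound 2 (0.70 log units; beyond the scatter), moved the number down, meaning compound 2 was the more toxic of the pair in this assay.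

Compound 3, `Cc1cc(-n2ccc3ccccc32)c2ncc(CSCCc3ccccc3)n2c1`, has not yet been measured. It differs from compound 2 in one place: 1H-indol-1-yl in place of 1H-imidazol-1-yl on an aromatic carbon. Among the compounds with values here, the only measured step, from compound 1 to compound 2, swapped one five-membered ring for another at this same position, but no step compares the 1H-imidazol-1-yl group with the 1H-indol-1-yl group, so it gives no direct guide. With nothing in the data pointing either way, the expected step of no change at the digits printed from compound 2 to compound 3 (within the scatter) in this assay is taken as none beyond the scatter. Compound 3 is therefore estimated at 20 ug/mL, with a likely range from 4 ug/mL to 100 ug/mL.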

Compound 3, minimum cytotoxic concentration: 100 ug/mL
Beside the measured number, compound 3's estimate is 5.0-fold (0.70 log units) below it, within the range that was stated.
By their numbers in this assay, from the lowest: compound 2; then compounds 1 and 3 (each within the scatter of the next).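

In this assay the new result shows that a ring joined through its nitrogen at this position does not by itself bring the lower number, since replacing 1H-imidazol-1-yl with 1H-indol-1-yl gives a 5.0-fold higher number from compound 2 to compound 3 (0.70 log units; beyond the scatter) on the same shared core. The entering 1H-indol-1-yl group has 9 heavy atoms and adds a six-membered aromatic ring of carbon only, yet the comparison with furan-3-yl shows no change at the digits printed from compound 1 to compound 3 (within the scatter) in this test, so this aromatic carbon carries the two-ring group without a lower number than the furan-3-yl compound gives. Among these three compounds, the lower number therefore appears only with 1H-imidazol-1-yl, and no accompanying measurement shows what lies behind that difference.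

The compounds shown leave open whether that lower number belongs to 1H-imidazol-1-yl alone or would also appear with other groups on this carbon, such as a simple amine, a pyridine ring or a carboxylic acid. They also leave open whether these same swaps would read the same way if another part of the shared core were changed.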